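Chloroquinoline imines: phenyl, chlorophenyl, thiophenyl variants

The compounds below may be only part of what the source reports. "The series", "measured", "known", "first", "only" and "open" are said of these compounds alone.

Compound 1 `Nc1nc(-c2ccccc2)cn1/N=C/c1cc2ccccc2nc1Cl` gives 49000 nM in a functional assay on MDA-MB-231 cells (Homo sapiens) for cytotoxicity, read by MTT assay, with a stated time of 48 h; on this read-out higher numbers stand for weaker inhibition and lower numbers for stronger inhibition. Compound 2 `Nc1nc(-c2ccc(Cl)cc2)cn1/N=C/c1cc2ccccc2nc1Cl` reaches only a limit of the assay, > 50000 nM, in this assay. The step of an at least 1.0-fold higher number from compound 1 to compound 2 (0.00 log units; that floor lies within the scatter) is bounded by the limit of > 50000 nM in this assay, at which 1 of the 2 values shown sits. Compound 3 `Nc1nc(-c2cccs2)cn1/N=C/c1cc2ccccc2nc1Cl` differs from compound 2 by thiophen-2-yl in place of 4-chlorophenyl on an aromatic carbon. Among the measured compounds shown here, only the step from compound 1 to compound 2 bears on it, and that step sits at a floor within the scatter, so no step beyond the scatter is expected in this assay; a further limit is as likely as a number. Compound 3 is expected near 50000 nM, within 20000 nM to 150000 nM, an expected step of a number no higher from compound 2 to compound 3 (the limit leaves the size open).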

Compound 3, half-maximal inhibitory concentration: > 50000 nM
Compound 3 was reported as a limit; the forecaster's own chance of this, stated with the estimate: 50%; the middle value sits exactly at the limit.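

Replacing phenyl with thiophen-2-yl at this position gives an at least 1.0-fold higher number from compound 1 to compound 3 (0.00 log units; that floor lies within the scatter), so a five-membered aromatic ring with a sulfur atom brings no readable gain in this assay. The step from compound 2 to compound 3 cannot be read because both values are limits: the limit of > 50000 nM in this assay, at which 2 of the 3 values shown sit.

From the compounds shown here alone, how compound 2 and compound 3 compare beyond that limit stays open. Also open, going by these compounds, is whether an amine or a carboxylic acid at this position would bring a number inside the range of this assay.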